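Cyano in Place of Methoxy: Estimating Compound 3

This account rests on a few compounds, and the source may have more. Where it says the series, first, only, none or still open, it means among the compounds named here.

Measured so far in a functional assay (muscle tissue) with Cavia porcellus as the target; on this read-out lower numbers stand for an effect already at smaller amounts and higher numbers for an effect only at larger amounts of compound:
- compound 1, `COC(=O)C1=C(C)N=C(C)/C(=C(\O)OC)C1c1cccc(OC)c1`, gives 191 nM
- compound 2, `COC(=O)C1=C(C)N=C(C)/C(=C(\O)OC)C1c1cccc(O)c1`, gives 1000 nM

Compound 1 holds the lowest of the two numbers in this assay. Among the measured compounds shown here, the only measured step, a 5.2-fold higher number from compound 1 to compound 2 (0.72 log units; beyond the scatter), comes from hydrogen in place of methyl on an oxygen on the aromatic ring, and it is described as modest yet beyond the scatter.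

Compound 3, `COC(=O)C1=C(C)N=C(C)/C(=C(\O)OC)C1c1cccc(C#N)c1`, has not yet been measured. It differs from compound 1 by cyano in place of methoxy on an aromatic carbon. For the measured compounds named here, the step from compound 1 to compound 2 is the one piece of evidence that bears on this change: it touches the same methoxy group, but swaps it for hydroxy rather than cyano, so it shows only that altering this group has so far moved the number upward. Compound 3 is therefore expected to give a somewhat higher number, estimated as a 2.4-fold higher number from compound 1 to compound 3 (0.37 log units; beyond the scatter). The estimate for compound 3 is 450 nM, with a range from 120 nM to 1700 nM.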

Compound 3, half-maximal effective concentration: 34.7 nM
Estimate against measurement, compound 3: 13-fold (1.11 log units) above; measured number below the stated range.
By their numbers in this assay, from the lowest: compound 3; then compound 1; then compound 2.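

In this assay, among the compounds shown here, the group at this place on the aromatic ring can push the number down as well as up: cyano in place of methoxy brings a 5.5-fold lower number from compound 1 to compound 3 (0.74 log units; beyond the scatter), whereas the only earlier step here went upward. Cyano in place of hydroxy gives a 29-fold lower number from compound 2 to compound 3 (1.46 log units; beyond the scatter), the only large step so far, so the three groups tried at this place now stand in a clear order, with cyano lowest, methoxy in the middle and hydroxy highest. Methoxy and cyano match in heavy atoms, hydrogen-bond donors and hydrogen-bond acceptors, so those counts alone do not settle the number here, and no measurement offered alongside these results explains what does.

The compounds shown contain no amine, carboxylic acid, chlorine or longer chain such as ethoxy at this place, so it remains open whether any of these would fall below or above cyano. As far as these compounds go, it is also open whether cyano would lower the number in the same way elsewhere on the ring or on a different core.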